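The source may report more compounds than this note shows. Statements on the series, on what has been measured and on what is new or still open speak of the compounds shown alone.

Compound 1 `Cc1c2cc[n+](C)cc2c(C)c2c3c([nH]c12)C=CC(=O)[C@@]31O[C@@H]2[C@H](O1)[C@@H](CO)O[C@H]2n1cnc2c(O)nc(N)nc21`: 0.8 uM
Compound 2 `Cc1c2cc[n+](C)cc2c(C)c2c3c([nH]c12)C=CC(=O)[C@@]31O[C@@H]2[C@H](O1)[C@@H](CO)O[C@H]2n1ccc(=O)[nH]c1=O`: > 3 uM

In a functional assay on L1210 cells (Mus musculus) for cytotoxicity (a lower number here means a stronger inhibitor, a higher number a weaker inhibitor), compound 1 gives 0.8 uM. For compound 2 this assay reports only a limit, > 3 uM (the limit of > 3 uM in this assay, at which 1 of the 2 values shown sits). The measured step is an at least 3.7-fold higher number from compound 1 to compound 2 (0.57 log units; beyond the scatter). Compound 3 `Cc1c2cc[n+](C)cc2c(C)c2c3c([nH]c12)C=CC(=O)[C@@]31O[C@@H]2[C@H](O1)[C@@H](CO)O[C@H]2n1ncc(=O)[nH]c1=O` differs from compound 2 by a group of 8 heavy atoms (3 carbon, 3 nitrogen, 2 oxygen; one six-membered aromatic ring with 3 hetero atoms) in place of a group of 8 heavy atoms (4 carbon, 2 nitrogen, 2 oxygen; one six-membered aromatic ring with 2 hetero atoms), on a saturated ring carbon. Going by the values given here, no measured step mirrors this exchange; the single measured step shows that swapping the group on this saturated ring carbon moved the number upward, so compound 3 is expected near compound 2 or weaker, likely again beyond the limit. Compound 3 is therefore estimated at 5 uM, between 2 uM and 15 uM. This corresponds to an expected step that the limit leaves unreadable from compound 2 to compound 3.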

Compound 3, concentration for 50% inhibition: > 3 uM
Compound 3: a limit, no number; the forecaster's own chance of this, stated with the estimate: 70%; the middle value is on the limit's open side.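

In this assay compound 3 gives only a limit, > 3 uM, so a second six-membered aromatic ring on this saturated ring carbon ends at the same limit: the limit of > 3 uM in this assay, at which 2 of the 3 values shown sit. Exchanging the group of compound 1 for this ring with 3 hetero atoms gives an at least 3.7-fold higher number from compound 1 to compound 3 (0.57 log units; beyond the scatter), so the loss seen with compound 2 is not confined to that one ring. Going by these compounds, the step between compound 2 and compound 3 cannot be read, as both values are limits, so any difference between these two rings stays open. Also open, on these data alone, is how adenine or a plain amine on this carbon would compare with the group of compound 1.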